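Sulfone series: removing the imidazolylcarbonyl amide for a hydroxyethyl amine

A few compounds are considered here, and "the series" means these few. Any claim that something is new, unique, unknown or untested is made for them only; others in the source may bear on it.

Measured compounds:
- compound 1, `NC[C@@H]1CCCc2cc(S(=O)(=O)c3cccc(F)c3)ccc21`: 0.0794 nM
- compound 2, `O=C(NC[C@@H]1CCCc2cc(S(=O)(=O)c3cccc(F)c3)ccc21)c1ccc[nH]1`: 5.01 nM
- compound 3, `O=C(NC[C@@H]1CCCc2cc(S(=O)(=O)c3cccc(F)c3)ccc21)c1ncc[nH]1`: 15.9 nM

In an assay on isolated protein for displacement of a labelled ligand from 5-hydroxytryptamine receptor 6 (Homo sapiens) (a higher number here means a weaker inhibitor, a lower number a stronger inhibitor), compound 3 gives the highest number of the three. Its nearest neighbour is compound 2, with a 3.2-fold higher number from compound 2 to compound 3 (0.50 log units; beyond the scatter); the gap to compound 1 is wider, with a 200-fold higher number from compound 1 to compound 3 (2.30 log units; beyond the scatter).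

Compound 4, `O=S(=O)(c1cccc(F)c1)c1ccc2c(c1)CCC[C@H]2CNCCO`, is not yet measured. It differs from compound 3 in one place: 2-hydroxyethyl in place of (1H-imidazol-2-yl)carbonyl on an amine nitrogen. The step removes the carbonyl-bearing ring from the amine nitrogen, so compound 4, like compound 1, carries an amine nitrogen that is not part of an amide. Going by the values given here, two measured steps bear on this: a 63-fold higher number from compound 1 to compound 2 (1.80 log units; beyond the scatter) and a 200-fold higher number from compound 1 to compound 3 (2.30 log units; beyond the scatter), both large, both in the direction of weaker binding on acylation of that nitrogen. Among the compounds with values here, no measured step shows what a 2-hydroxyethyl on that nitrogen does on its own, so the expectation rests on reversing the acylation.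

In this assay compound 4 is therefore expected to give a markedly lower number than compound 3, with a 40-fold lower number from compound 3 to compound 4 (1.60 log units; beyond the scatter), though probably not all the way back to compound 1 given 0.0794 nM. The estimate for compound 4 is 0.4 nM, within 0.06 nM to 3 nM.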

Compound 4, inhibition constant: 0.126 nM
Beside the measured number, compound 4's estimate is 3.2-fold (0.50 log units) above it; the measured number falls inside the stated range.
By their numbers in this assay, from the lowest: compounds 1 and 4 (each within the scatter of the next); then compound 2; then compound 3.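

In this assay, the amine nitrogen accepts a 2-hydroxyethyl group with no reading beyond the scatter, a 1.6-fold higher number from compound 1 to compound 4 (0.20 log units; within the scatter). Both amides stand far from compound 4, a 130-fold lower number from compound 3 to compound 4 (2.10 log units; beyond the scatter) and a 40-fold lower number from compound 2 to compound 4 (1.60 log units; beyond the scatter), so among these compounds the large steps go with the two acyl groups and not with substitution on that nitrogen as such. Nothing measured here gives a reason for this difference.

On these data alone, whether the hydroxyl of the 2-hydroxyethyl group contributes remains open, and a plain ethyl or a 2-methoxyethyl group on the same nitrogen would address that, while a 3-hydroxypropyl group would test a longer chain. As far as these compounds go, it is also open whether an acetyl group, an acyl group without a ring, gives steps as large as those of the pyrrole and imidazole amides.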